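The compounds below may be only part of what the source reports. "The series", "measured", "known", "first", "only" and "open" are said of these compounds alone.

Two compounds of the series carry a cyclopropyl-oxazole on a phenylsulfonyl group attached to a fused bicyclic amine. Compound 1 `CC1Cc2ccccc2N1S(=O)(=O)c1ccc(-c2cnc(C3CC3)o2)cc1` gives 81.8% in a functional assay on BGC-823 cells (Homo sapiens) for inhibition, read by MTT assay, tested at 10 uM; on this read-out higher numbers stand for more inhibition at the one concentration tested (going by the name of the read-out) and lower numbers for less inhibition. Compound 2 `Cc1ccc2c(c1)CCN2S(=O)(=O)c1ccc(-c2cnc(C3CC3)o2)cc1` gives 79.1% in this assay; the two numbers lie within the scatter of each other, so the pair shows no separation on this read-out. Among the compounds with values here, compound 2 is therefore one of two closely matched measurements, with compound 1 the only comparison available.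

The next compound, compound 3 `CS(=O)(=O)c1ccc2c(c1)CCN2S(=O)(=O)c1ccc(-c2cnc(C3CC3)o2)cc1`, differs from compound 2 in one place: methylsulfonyl in place of methyl on an aromatic carbon. Within the data shown here, no measured pair covers a change of this kind, so there is no step to lean on. The working expectation is a step of small size, if any, most likely a modest move downward but not clearly beyond the scatter; the expected step is a number 7.1 percentage points lower from compound 2 to compound 3 (within the scatter). On that basis compound 3 is estimated to give 72% in this assay, with a range from 50% to 88%.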

Compound 3, a percentage reported as inhibition, at one concentration (the size of the read-out at that concentration, not a potency): 28.3%
Compound 3: the middle estimate sits 43.7 percentage points above what was measured; the whole stated range lies above it.
By their numbers in this assay, from the lowest: compound 3; then compounds 2 and 1 (each within the scatter of the next).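

In this assay, methylsulfonyl in place of methyl on this aromatic carbon gives a number 50.8 percentage points lower from compound 2 to compound 3 (beyond the scatter), so this position of the fused system is not indifferent to what it carries, which compound 1 and compound 2 alone could not show. The entering methylsulfonyl differs from the leaving methyl at once in heavy atoms, in its sulfur and oxygen atoms and in hydrogen-bond acceptors, and this single step cannot separate these differences. Nothing at hand accounts for the size of the step.

On these data alone, it remains open whether the loss of inhibition belongs to methylsulfonyl itself or extends to other groups on this carbon, such as a plain hydrogen, a methoxy group, an amine, a nitrile or a carboxylic acid, and whether a larger alkyl chain would behave like methyl. Also open, as far as these compounds go, is whether the same change would cost as much on the core of compound 1, and how the step would look across a range of concentrations rather than at the one concentration tested.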